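Swapping an allyl chain for a furan ring on an amidine

The source may hold more compounds than are shown below. What is called first, only, known or untested is meant among the compounds shown, and "the series" means these compounds.

Within the data shown here, compound 2 `C=CCCN(C1=NCCN1)c1c(Br)cccc1Br` gives 11.2 in a physicochemical assay for acid dissociation, the higher of the two numbers measured so far; compound 1 `C=CCN(C1=NCCN1)c1c(Br)cccc1Br` gives 10.7. Among the measured compounds shown here, the one measured step, a number 0.50 log units higher from compound 1 to compound 2 (beyond the scatter), concerns a longer chain, not a ring. Compound 3 `Brc1cccc(Br)c1N(Cc1ccco1)C1=NCCN1` differs from compound 2 in one place: furan-2-yl in place of allyl on a saturated chain carbon bound to a nitrogen on an aromatic ring. For the measured compounds named here, no measured step bears directly on this change, so only a small shift is expected, if any; the estimate for compound 3 is a step of a number 0.40 log units lower from compound 2 to compound 3 (beyond the scatter). Compound 3 is therefore expected to give about 10.8, most likely between 10.2 and 11.4.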

Compound 3, acid dissociation constant: 10.5
Beside the measured number, compound 3's estimate is 0.30 log units above it, within the range that was stated.
By their numbers in this assay, from the lowest: compounds 3 and 1 (each within the scatter of the next); then compound 2.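

In this assay, this position now responds to a ring as well as to a chain: furan-2-yl in place of allyl gives a number 0.70 log units lower from compound 2 to compound 3 (beyond the scatter). Furan-2-yl in place of vinyl gives a number 0.20 log units lower from compound 1 to compound 3 (within the scatter), so compound 3 and compound 1 cannot be told apart here, and only compound 2 stands apart from both. Nothing available explains why these groups give these numbers. Still open, as far as these compounds go, is where a phenyl ring or a saturated ring such as tetrahydrofuran-2-yl would fall, and whether a longer chain would extend the difference between vinyl and allyl.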